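The compounds below may be only part of what the source reports. "The series", "measured", "known", "first", "only" and "open" are said of these compounds alone.

Measured compounds in this set:
- compound 1 `Brc1ccc(Oc2cc(Br)cc(Br)c2OCCCCCN2CCN(C/C=C/c3ccccc3)CC2)c(Br)c1` — 32.7 ug/mL
- compound 2 `C#CCOc1c(Br)cc(Br)cc1Oc1ccc(Br)cc1Br` — 29.5 ug/mL
- compound 3 `CC(C)(C)OC(=O)N1CCN(CCCCCOc2c(Br)cc(Br)cc2Oc2ccc(Br)cc2Br)CC1` — 35.5 ug/mL

In a functional assay on U-937 cells (Homo sapiens) for cytotoxicity, read by MTT assay, with a stated time of 24 h (a higher number here means a weaker inhibitor, a lower number a stronger inhibitor), compound 2 gives 29.5 ug/mL, the lowest of the three numbers shown, but its gaps to compound 1 and to compound 3 are both within the scatter. The unmeasured compound 4 `CC(C)(C)C(=O)C(C#N)Oc1c(Br)cc(Br)cc1Oc1ccc(Br)cc1Br` differs from compound 2 by cyano((tert-butyl)carbonyl)methyl in place of propargyl on an oxygen on an aromatic ring. Within the data shown here, the only measured step, a 1.1-fold higher number from compound 1 to compound 3 (0.04 log units; within the scatter), lies at an amine nitrogen in a ring rather than on the aryl oxygen, so it bears only loosely on this change, and it was within the scatter. Since three quite different substituents on the shared core give numbers within the scatter of one another, compound 4 is expected to stay close to compound 2, with a 1.0-fold higher number from compound 2 to compound 4 (0.01 log units; within the scatter) not beyond the scatter. Compound 4 is therefore estimated at 30 ug/mL, in a range from 15 ug/mL to 60 ug/mL.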

Compound 4, half-maximal inhibitory concentration: 32.5 ug/mL
Compound 4: middle estimate off by 1.1-fold (0.03 log units), on the low side; the range from low to high includes it.
By their numbers in this assay, from the lowest: compounds 2, 4, 1 and 3 (each within the scatter of the next).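

In this assay, among these compounds, the step of a 1.1-fold higher number from compound 2 to compound 4 (0.04 log units; within the scatter) gives the first direct reading at the aryl oxygen, where earlier compounds offered only a step at a ring amine nitrogen. Here, cyano((tert-butyl)carbonyl)methyl in place of propargyl, a group with more heavy atoms that carries a nitrile and a carbonyl, stays within the scatter. The shared core thus tolerates this exchange on that oxygen in this assay.

Going by these compounds, whether an amine or a carboxylic acid on this oxygen would move the number beyond the scatter remains open. No measurement here bears on why the exchange leaves the number within the scatter.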